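The compounds below may be only part of what the source reports. "The series", "measured", "known", "first", "only" and "open" are said of these compounds alone.

Measured compounds in a functional assay on HepG2 cells (Homo sapiens) for cytotoxicity, read by MTT assay, with a stated time of 48 h; on this read-out lower numbers stand for stronger inhibition and higher numbers for weaker inhibition:
Compound 1 `C=CCSc1nnc(-c2cc(OC)c(OC)c(OC)c2)n1N1C(=O)c2ccccc2C1=O`: > 200000 nM, a limit of the assay.
Compound 2 `COc1cc(-c2nnc(SCC(=O)c3ccc(C)cc3)n2N2C(=O)c3ccccc3C2=O)cc(OC)c1OC`: 9440 nM.
Compound 3 `COc1cc(-c2nnc(SCC(=O)c3ccc(F)cc3)n2N2C(=O)c3ccccc3C2=O)cc(OC)c1OC`: > 200000 nM, a limit of the assay.

Compound 3 stands at the limit of this assay and has no number of its own. Within the data shown here, compound 2 holds the only read number in the set, and the step of an at least 21-fold higher number from compound 2 to compound 3 (1.32 log units; beyond the scatter) is large, toward a higher number. The step that the two limits leave unreadable from compound 1 to compound 3 links two limits and carries no readable size. The change to compound 4 `COc1cc(-c2nnc(SCC(=O)c3ccc(F)c(F)c3)n2N2C(=O)c3ccccc3C2=O)cc(OC)c1OC` is fluoro in place of hydrogen on an aromatic carbon. Among the measured compounds shown here, no measured step swaps hydrogen for fluoro on that ring; the one step that brings fluoro in, an at least 21-fold higher number from compound 2 to compound 3 (1.32 log units; beyond the scatter), went to the limit at which two of the three values sit (the limit of > 200000 nM in this assay, at which 2 of the 3 values shown sit). With compound 3 already at that limit, compound 4 is expected to remain there, and the expected step that the limit leaves unreadable from compound 3 to compound 4 is nothing readable beyond the scatter. The estimate for compound 4 in this assay is 250000 nM, with a range from 60000 nM to 1000000 nM.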

Compound 4, half-maximal inhibitory concentration: > 200000 nM
Compound 4: no number, only a limit; the forecaster's own chance of this, stated with the estimate: 70%; the middle value lies beyond the limit too.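

In this assay compound 4 gives > 200000 nM, a limit of the assay and not a number. The exchange of 4-methylphenyl for 3,4-difluorophenyl on the carbonyl carbon gives an at least 21-fold higher number from compound 2 to compound 4 (1.32 log units; beyond the scatter), so among the aryl groups shown on that carbonyl, only the 4-methylphenyl of compound 2 yields a read number. The steps from compound 1 and compound 3 to compound 4 cannot be read, which leaves the fluoro added ortho to a fluoro group without a measurable result, and the series now rests mostly on one limit: the limit of > 200000 nM in this assay, at which 3 of the 4 values shown sit.

As far as these compounds go, it remains open whether the read number of compound 2 depends on the methyl group itself. An ethyl group or an amine in its place on the same ring would bear on this.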